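Removing a Ring Hydroxy from a Bicyclic Lactone Core

A few compounds are considered here, and "the series" means these few. Any claim that something is new, unique, unknown or untested is made for them only; others in the source may bear on it.

Compound 1, `C=C1C(=O)O[C@H]2CC[C@@H](C)CC[C@@H]12`: 69%
Compound 2, `C=C1C(=O)O[C@H]2[C@@H](O)CCCC[C@@H]12`: 40%
Compound 3, `CC1=C2CCCCC[C@@H]2OC1=O`: 4%

These three compounds were tested in a functional assay on P388 cells (Mus musculus) for inhibition, with a stated time of 48 h, tested at 1 ug/mL; a lower number here means a weaker effect, a higher number a stronger effect of the compound at the concentration tested. Among the three numbers, compound 2 stands second highest. Its nearest neighbour is compound 1, whose number lies higher by a margin beyond the usual scatter; its furthest is compound 3, whose number lies lower, also beyond the scatter.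

The unmeasured compound 4, `C=C1C(=O)O[C@H]2CCCCC[C@@H]12`, differs from compound 2 in one place only: hydrogen in place of hydroxy on a saturated ring carbon. The hydroxy group leaves and a hydrogen atom takes its place on the saturated ring carbon of the seven-membered ring.

Within the data shown here, no single-place step between measured compounds is available to guide the size of this change. What can be said is that compound 1, which also carries no hydroxy on its ring, gives 69% in this assay, whereas compound 2 gives 40%. Compound 1 differs from compound 2 in more than one place, so this pair only hints at direction. On that basis the step of a number 15 percentage points higher from compound 2 to compound 4 (beyond the scatter) is expected to be an increase beyond the scatter. Compound 4 is estimated at 55%, with a range from 30% to 80%.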

Compound 4, a percentage reported as activity, at one concentration (the size of the read-out at that concentration, not a potency): 76%
Compound 4: middle estimate off by 21 percentage points, on the low side; the measured number falls inside the stated range.
By their numbers in this assay, from the lowest: compound 3; then compound 2; then compounds 1 and 4 (each within the scatter of the next).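

In this assay, the change from hydroxy to hydrogen on a saturated ring carbon of the seven-membered ring, next to the ring atom that bears a fused ring, gives a number 36 percentage points higher from compound 2 to compound 4 (beyond the scatter). Among these compounds, this is the first direct measure of the change, since the earlier comparison between compound 1 and compound 2 involved more than one difference and could suggest only a direction; the step is large, so in this pair the hydroxy is clearly linked to the lower read-out at the concentration tested. The new compound also provides a second clean comparison, hydrogen in place of methyl on a saturated ring carbon, which gives a number 7 percentage points higher from compound 1 to compound 4 (within the scatter), so that change cannot be told apart from ordinary assay variation.

The data at hand offer no explanation for the large hydroxy step. As far as these compounds go, it also remains open how a methoxy group, a fluorine atom or an amine on the same ring carbon would compare with the hydroxy and hydrogen, and whether a longer chain in place of the methyl of compound 1 would still match compound 4.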